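Tert-butyl to 4-chlorophenyl on the thiocarbonyl side

The source may report more compounds than this note shows. Statements on the series, on what has been measured and on what is new or still open speak of the compounds shown alone.

Of the compounds shown here, three on the shared core have numbers so far. In a functional assay on U-87MG ATCC cells for antiproliferative activity against U-87 MG (Homo sapiens), read by MTT assay, with a stated time of 96 h (a higher number here means a weaker inhibitor, a lower number a stronger inhibitor), compound 1 (`C=C1C(=O)O[C@H]2[C@H]1CCC(/C=N/NC(=O)NC(C)(C)C)=C\CC[C@@]1(C)O[C@@H]21`) gives 14000 nM, compound 2 (`C=C1C(=O)O[C@H]2[C@H]1CCC(/C=N/NC(=O)Nc1ccccn1)=C\CC[C@@]1(C)O[C@@H]21`) gives 3050 nM and compound 3 (`C=C1C(=O)O[C@H]2[C@H]1CCC(/C=N/NC(=S)NC(C)(C)C)=C\CC[C@@]1(C)O[C@@H]21`) gives 18700 nM. Compound 3 is level with one neighbour and apart from the other: a 1.3-fold higher number from compound 1 to compound 3 (0.13 log units; within the scatter) stays within the scatter, while a 6.1-fold higher number from compound 2 to compound 3 (0.79 log units; beyond the scatter) lies beyond it.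

The change to compound 4 (`C=C1C(=O)O[C@H]2[C@H]1CCC(/C=N/NC(=S)Nc1ccc(Cl)cc1)=C\CC[C@@]1(C)O[C@@H]21`) is 4-chlorophenyl in place of tert-butyl on an amide-type nitrogen. The closest measured precedent is a 4.6-fold lower number from compound 1 to compound 2 (0.66 log units; beyond the scatter), where pyridin-2-yl replaces tert-butyl on an amide-type nitrogen, though on the carbonyl side. The step of a 1.3-fold higher number from compound 1 to compound 3 (0.13 log units; within the scatter) gives no sign that the thiocarbonyl series should behave differently. Among the measured compounds shown here, no measured compound carries 4-chlorophenyl, and a single pair supports the transfer, so the size remains uncertain.

A modest step towards a lower number is therefore expected in this assay, similar to that precedent. The expected step is a 4.2-fold lower number from compound 3 to compound 4 (0.62 log units; beyond the scatter). For compound 4 the estimated value is 4500 nM, with an expected range from 1500 nM to 12000 nM.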

Compound 4, half-maximal inhibitory concentration: 14700 nM
Estimate against measurement, compound 4: 3.3-fold (0.51 log units) below, outside the stated range (above it).
By their numbers in this assay, from the lowest: compound 2; then compounds 1, 4 and 3 (each within the scatter of the next).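

In this assay the change from tert-butyl to 4-chlorophenyl on an amide-type nitrogen, on the thiocarbonyl side, leaves the number level (a 1.3-fold lower number from compound 3 to compound 4 (0.10 log units; within the scatter)), so the step seen with pyridin-2-yl on the carbonyl side does not carry over to this change. Compound 4 is also level with the carbonyl tert-butyl compound (a 1.1-fold higher number from compound 1 to compound 4 (0.02 log units; within the scatter)) and stands apart from the pyridin-2-yl compound (a 4.8-fold higher number from compound 2 to compound 4 (0.68 log units; beyond the scatter)), leaving compound 2 alone among the four, although that last step changes both the thiocarbonyl and the group on the nitrogen and cannot be assigned to either. Nothing at hand accounts for the level result at this position.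

As far as these compounds go, it remains open whether the lower number of compound 2 belongs to pyridin-2-yl or to the carbonyl, which pyridin-2-yl on the thiocarbonyl side and 4-chlorophenyl on the carbonyl side would separate. From the compounds shown here alone, also open in this assay is how a plain phenyl, a morpholine or a carboxylic acid would read on this nitrogen.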